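This account rests on a few compounds, and the source may have more. Where it says the series, first, only, none or still open, it means among the compounds named here.

Compound 2, `O=c1n(Cc2cc3cc(Br)ccc3n2CCCCO)c2cnccc2n1C1CC1`, is the starting point. In an ADME assay on HeLa cells (Homo sapiens) for cytotoxicity, read by ATP content, with a stated time of 3 days (a higher number here means that more compound is tolerated, a lower number that less compound is tolerated), compound 2 gives > 50000 nM, which is a limit of the assay. Compound 1, `O=c1n(Cc2cc3cc(Cl)ccc3n2CCCCO)c2cnccc2n1C1CC1`, gives > 50000 nM in this assay, also a limit. Compound 3, `N#CCCCn1c(Cn2c(=O)n(-c3ccc(C(=O)NC4CC4)cc3)c3ccncc32)cc2cc(Cl)ccc21`, gives > 50000 nM in this assay, again a limit. Within the data shown here, the one change between measured compounds, a step that the two limits leave unreadable from compound 1 to compound 2, cannot be read in size because the limit of > 50000 nM in this assay, at which 3 of the 3 values shown sit, leaves no room for a step to show itself. Compound 4, `COc1ccc2c(c1)cc(Cn1c(=O)n(C3CC3)c3ccncc31)n2CCCCO`, differs from compound 2 by methoxy in place of bromo on an aromatic carbon. Among the measured compounds shown here, no measured step bears directly on such a change, and the single step that exists is unreadable, so there is no ground for expecting a shift in this assay beyond the scatter in either direction. Compound 4 is therefore expected to sit at 60000 nM in this assay, within a range of 30000 nM to 150000 nM, and most likely to be reported once more as a limit. The expected step that the limit leaves unreadable from compound 2 to compound 4 is accordingly none beyond the scatter.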

Compound 4, half-maximal cytotoxic concentration: > 50000 nM
Compound 4 ended at the assay's limit; the forecaster's own chance of this, stated with the estimate: 85%; the middle value does not contradict the limit.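

The steps to compound 4 from compound 2 and from compound 1 cannot be read, because each of these compounds stands at a limit: the limit of > 50000 nM in this assay, at which 4 of the 4 values shown sit.

The compounds shown leave open whether methoxy, bromo or chloro on that aromatic carbon makes any difference in this assay.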